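This account rests on a few compounds, and the source may have more. Where it says the series, first, only, none or still open, it means among the compounds named here.

Four compounds built on one scaffold were compared in a functional assay on MCF7 cells (Homo sapiens) for inhibition, read by MTT assay, with stated times of 18 h and 4 h; a higher number here means a weaker inhibitor, a lower number a stronger inhibitor. Compound 1 `CCCOP(=O)(O)OCCSC(=S)N1CCCCC1` gives only a limit there: in this assay compound 1 gives > 100000 nM, which is a limit of the assay rather than a number, as recorded by the limit of > 100000 nM in this assay, at which 1 of the 3 values shown sits. Compound 2 `CCCCCCOP(=O)(O)OCCSC(=S)N1CCCCC1` gives 62000 nM in this assay. Compound 3 `CCCCCCOP(=O)(O)OCCSC(=S)N1CCN(C)CC1` gives 58000 nM in this assay. The cores of compound 2 and compound 3 differ by 4-methylpiperazin-1-yl in place of piperidin-1-yl on a thiocarbonyl carbon, and that step, a 1.1-fold lower number from compound 2 to compound 3 (0.03 log units; within the scatter), sits within the scatter, so the two values cannot be ordered. Compound 2 and compound 1 differ by hydrogen in place of propyl on a saturated chain carbon, three bonds along the chain from an oxygen on an unsaturated carbon, a change that produced an at least 1.6-fold higher number from compound 2 to compound 1 (0.20 log units; that floor lies within the scatter). Compound 4 `CCCOP(=O)(O)OCCSC(=S)N1CCN(C)CC1` carries the core of compound 3 with the same change, (hydrogen in place of propyl on a saturated chain carbon, three bonds along the chain from an oxygen on an unsaturated carbon), made on it. Compound 3 shows 58000 nM in this assay. Given the earlier step of an at least 1.6-fold higher number from compound 2 to compound 1 (0.20 log units; that floor lies within the scatter), compound 4 is expected to show the estimated step of a 1.7-fold higher number from compound 3 to compound 4 (0.24 log units; within the scatter). The estimate for compound 4 is therefore 100000 nM, with an expected range from 60000 nM to 200000 nM.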

Compound 4, half-maximal inhibitory concentration: 59000 nM
For compound 4 the middle estimate is 1.7-fold (0.23 log units) above the measured one; measured number outside the range, below it.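

On the core of compound 3, exchanging the hexyl chain for a propyl chain gives a 1.0-fold higher number from compound 3 to compound 4 (0.01 log units; within the scatter), so in this assay these two values cannot be ordered and this core shows no measurable effect of the change. Compound 1 gives > 100000 nM, which is a limit of the assay and not a number. The result therefore does not show that the change behaves the same way on both cores, nor does it show that the cores respond differently, so nothing firm can be said about carrying it from one core to the other: the same change on two cores in this assay, an at least 1.6-fold higher number (0.20 log units; that floor lies within the scatter) from compound 2 to compound 1 and a 1.0-fold higher number (0.01 log units; within the scatter) from compound 3 to compound 4; the limit leaves it open whether they differ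

The compounds shown leave open what a chain longer than hexyl, or a chain ending in an amine or a carboxylic acid, would give on either core in this assay. They also leave open how a morpholine in place of the piperidin-1-yl or 4-methylpiperazin-1-yl group on the thiocarbonyl carbon would read in this assay.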